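Benzofuran in place of thiophene on a long-chain threonine amide

A few compounds are considered here, and "the series" means these few. Any claim that something is new, unique, unknown or untested is made for them only; others in the source may bear on it.

Measured compounds:
compound 1 `CCCCCCCCCCCCNC(=O)[C@@H](NC(=O)c1cc2ccccc2o1)[C@@H](C)O` gives 12900 nM in a functional assay on SiHa cells (Homo sapiens) for cytotoxicity, read by MTT assay, with a stated time of 48 h; on this read-out higher numbers stand for weaker inhibition and lower numbers for stronger inhibition
compound 2 `CCCCCCCCCCCCCCNC(=O)[C@@H](NC(=O)c1ccccc1)[C@@H](C)O` gives > 200000 nM in this assay, which is a limit and not a number
compound 3 `CCCCCCCCCCCCCCNC(=O)[C@@H](NC(=O)c1cccs1)[C@@H](C)O` gives 63000 nM in this assay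

Among the two values that are numbers, compound 3 has the highest, with compound 1 at a lower value beyond the scatter. The step to compound 4 `CCCCCCCCCCCCCCNC(=O)[C@@H](NC(=O)c1cc2ccccc2o1)[C@@H](C)O` is 1-benzofuran-2-yl in place of thiophen-2-yl on a carbonyl carbon. Among the compounds with values here, one measured step bears on it: an at least 3.1-fold lower number from compound 2 to compound 3 (0.50 log units; beyond the scatter), where a five-membered ring replaced a six-membered one and the number fell; but that step starts from a limit (the limit of > 200000 nM in this assay, at which 1 of the 3 values shown sits), so its full size is not known. Compound 1 carries the same 1-benzofuran-2-yl group as compound 4, differing only in the shorter dodecyl chain, and its value sits well below that of compound 3. On that basis compound 4 is expected to show a lower number than compound 3, with a 4.2-fold lower number from compound 3 to compound 4 (0.62 log units; beyond the scatter) as the estimated step. The estimate for compound 4 in this assay is 15000 nM, expected to lie between 5000 nM and 50000 nM.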

Compound 4, half-maximal inhibitory concentration: 14200 nM
Estimate against measurement, compound 4: 1.1-fold (0.02 log units) above; the range from low to high includes it.
By their numbers in this assay, from the lowest: compounds 1 and 4 (each within the scatter of the next); then compound 3. At a limit, above all of these: compound 2.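

On the carbonyl carbon, swapping thiophen-2-yl for the larger 1-benzofuran-2-yl group gives, in this assay, a 4.4-fold lower number from compound 3 to compound 4 (0.65 log units; beyond the scatter), so adding a six-membered aromatic ring to the five-membered one goes with stronger inhibition here. From the compounds shown here alone, measured against phenyl, the same group gives an at least 14-fold lower number from compound 2 to compound 4 (1.14 log units; beyond the scatter), but the full size of this step is unknown, as it starts from a limit: the limit of > 200000 nM in this assay, at which 1 of the 4 values shown sits. With 1-benzofuran-2-yl in place, the chain difference, an ethyl in place of hydrogen on a saturated chain carbon, does not separate the two compounds, with a 1.1-fold higher number from compound 1 to compound 4 (0.04 log units; within the scatter).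

These compounds cannot show whether the gain follows the added ring or the oxygen that replaces sulfur, which a furan-2-yl or 1-benzothiophen-2-yl group could help to separate. Going by these compounds, how a longer chain would behave also remains open.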